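Swapping the triazole diol arm for a piperazine arm

A few compounds are considered here, and "the series" means these few. Any claim that something is new, unique, unknown or untested is made for them only; others in the source may bear on it.

- Compound 1 `O=C1c2c[n+]([O-])c3ccccc3c2C(=O)c2c1c1ccccc1n2Cc1cn([C@H]2O[C@H](CO)[C@@H](O)[C@H]2O)nn1`: 1700 nM
- Compound 2 `O=C1c2c[n+]([O-])c3ccccc3c2C(=O)c2c1c1ccccc1n2CCCCn1ccnc1`: 210 nM
- Compound 3 `O=C1c2c[n+]([O-])c3ccccc3c2C(=O)c2c1c1ccccc1n2Cc1cn(C[C@H](O)CO)nn1`: 1310 nM

In a functional assay on MDA-MB-231 cells (Homo sapiens) for cytotoxicity, read by MTT assay, with a stated time of 72 h (a lower number here means a stronger inhibitor, a higher number a weaker inhibitor), compound 3 gives 1310 nM. It is level with compound 1 within the usual scatter, a 1.3-fold lower number from compound 1 to compound 3 (0.11 log units; within the scatter), and it is clearly weaker than compound 2, a 6.2-fold higher number from compound 2 to compound 3 (0.80 log units; beyond the scatter).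

Compound 4 `O=C1c2c[n+]([O-])c3ccccc3c2C(=O)c2c1c1ccccc1n2CCCCN1CCNCC1` has not been measured. The change is 3-(piperazin-1-yl)propyl in place of 1-(2,3-dihydroxypropyl)-1H-1,2,3-triazol-4-yl on a saturated chain carbon bound to an aromatic nitrogen. The best guide is compound 2, which holds 3-(1H-imidazol-1-yl)propyl at that place, so the step of a 6.2-fold higher number from compound 2 to compound 3 (0.80 log units; beyond the scatter) can be read backwards. Among the measured compounds shown here, the step of a 1.3-fold lower number from compound 1 to compound 3 (0.11 log units; within the scatter) shows only that changing the group on the triazole made no difference beyond the scatter. For the measured compounds named here, no measured compound carries a piperazine, so the guide is loose. A drop in the number of similar but somewhat smaller size is expected, a 4.1-fold lower number from compound 3 to compound 4 (0.61 log units; beyond the scatter). For compound 4 the estimated value is 320 nM, with an expected range of 100 nM to 1000 nM.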

Compound 4, half-maximal inhibitory concentration: 3310 nM
Beside the measured number, compound 4's estimate is 10-fold (1.01 log units) below it; measured number outside the range, above it.
By their numbers in this assay, from the lowest: compound 2; then compounds 3, 1 and 4 (each within the scatter of the next, the first and the last beyond it).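

In this assay, the piperazine arm brings no gain over the triazole diol arm, giving a 2.5-fold higher number from compound 3 to compound 4 (0.40 log units; beyond the scatter). The sharper reading comes from the pair that shares the same chain and differs only in the ring at its end, where piperazin-1-yl in place of 1H-imidazol-1-yl gives a 16-fold higher number from compound 2 to compound 4 (1.20 log units; beyond the scatter). The chain alone therefore does not secure the low number of compound 2, and at this position the terminal ring makes a large difference; nothing available here explains why.

The compounds shown leave open whether the low number is particular to imidazole or would also appear with another terminal ring, such as a morpholine or a 1,2,4-triazole. They also leave open how a shorter or longer chain would behave with either ring.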